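Trifluoromethyl Replaces Fluoropyridyl: Expected Oral Exposure

The compounds below may be only part of what the source reports. "The series", "measured", "known", "first", "only" and "open" are said of these compounds alone.

Compound 1 `O=C(Nc1ccc(F)c(-c2nc3ncc(-c4ccccc4F)cc3[nH]2)c1)N1CCCC1`: 2230 nM
Compound 2 `O=C(Nc1ccc(F)c(-c2nc3ncc(-c4cccnc4F)cc3[nH]2)c1)N1CCCC1`: 25600 nM

In an ADME assay on the whole organism (Mus musculus, strain Swiss Webster) for pharmacokinetics, read by LC-MS, at a dose of 50 mg/kg by the oral route (on this read-out lower numbers stand for lower exposure and higher numbers for higher exposure at the dose given), compound 1 gives 2230 nM and compound 2 gives 25600 nM, the higher of the two numbers, separated by the step of an 11-fold higher number from compound 1 to compound 2 (1.06 log units; beyond the scatter). Compound 3 `O=C(Nc1ccc(F)c(-c2nc3ncc(C(F)(F)F)cc3[nH]2)c1)N1CCCC1` differs from compound 2 in one place: trifluoromethyl in place of 2-fluoropyridin-3-yl on an aromatic carbon. Within the data shown here, the only measured step, an 11-fold higher number from compound 1 to compound 2 (1.06 log units; beyond the scatter), exchanges one six-membered aromatic ring for another and so does not cover a change to a group without a ring; the direction of this change is therefore uncertain. Compound 3 is expected to give roughly 15000 nM, within 4000 nM to 50000 nM. This estimate means a step of a 1.7-fold lower number from compound 2 to compound 3 (0.23 log units; within the scatter).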

Compound 3, maximal plasma concentration: 1080 nM
Compound 3: the middle estimate sits 14-fold (1.14 log units) above what was measured; the whole stated range lies above it.
By their numbers in this assay, from the lowest: compound 3; then compound 1; then compound 2.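

In this assay, the change from a ring to trifluoromethyl, a group without a ring, gives a 24-fold lower number from compound 2 to compound 3 (1.37 log units; beyond the scatter) and also a 2.1-fold lower number from compound 1 to compound 3 (0.31 log units; beyond the scatter) at this carbon. The number therefore falls from both ring-bearing compounds, and the step is much larger from the 2-fluoropyridin-3-yl compound than from the 2-fluorophenyl compound. Nothing available explains either step.

On these data alone, whether a methyl, a nitrile or an amine at this carbon would stay near compound 3 or approach compound 2 remains open. So does whether the trifluoromethyl result holds on other cores.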